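Swapping chloro for cyano: a lipophilicity estimate

This account rests on a few compounds, and the source may have more. Where it says the series, first, only, none or still open, it means among the compounds named here.

Compound 1 `CC(C)OC[C@H](Oc1ncnc2c1cnn2-c1ccccc1Cl)C(=O)Nc1ccc(C#N)cn1` gives 3.5
Compound 2 `CC(C)OC[C@H](Oc1ncnc2c1cnn2-c1ncccc1Cl)C(=O)Nc1ccc(Cl)cn1` gives 3.5
Compound 3 `CCOC[C@H](Oc1ncnc2c1cnn2-c1ncccc1Cl)C(=O)Nc1ccc(Cl)cn1` gives 3

In a physicochemical assay for lipophilicity (a higher number here means a more lipophilic compound, a lower number a more polar compound), compound 2 gives 3.5 and stands level with compound 1, the two sharing the highest of the three numbers. Compound 4 `CC(C)OC[C@H](Oc1ncnc2c1cnn2-c1ncccc1Cl)C(=O)Nc1ccc(C#N)cn1` differs from compound 2 in one place: cyano in place of chloro on an aromatic carbon, turning 5-chloropyridin-2-yl into 5-cyanopyridin-2-yl cyano in place of chloro on an aromatic carbon and leaving the rest untouched.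

Within the data shown here, no measured pair isolates this swap. Among the measured compounds shown here, the only single-place step available is a number 0.50 log units lower from compound 2 to compound 3 (beyond the scatter) and it comes from hydrogen in place of methyl on the side chain, so it offers a sense of scale and no more. Compound 1 already carries 5-cyanopyridin-2-yl and differs from compound 4 only at the aromatic ring on the shared core. The value of compound 1, 3.5, shows that a cyano compound in this set can reach this height, so the range must stay wide.

A modest fall of similar scale is still the expectation, and the expected move is a number 0.60 log units lower from compound 2 to compound 4 (beyond the scatter) in this assay here. The estimate for compound 4 is 2.9 as a middle value, with an expected range from 2.5 to 3.3 for the measurement.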

Compound 4, distribution coefficient: 2.5
Estimate against measurement, compound 4: 0.40 log units above; the measured number falls inside the stated range.
By their numbers in this assay, from the lowest: compound 4; then compound 3; then compounds 1 and 2 (each within the scatter of the next).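

In this assay, turning 5-chloropyridin-2-yl into 5-cyanopyridin-2-yl gives a number 1.00 log units lower from compound 2 to compound 4 (beyond the scatter), so this ring carbon, two atoms from the ring nitrogen and para to a large group, clearly matters for the number. A change elsewhere matters just as much: 3-chloropyridin-2-yl in place of 2-chlorophenyl on an aromatic nitrogen gives a number 1.00 log units lower from compound 1 to compound 4 (beyond the scatter), a step of the same printed size. Compound 1 and compound 4 both carry the cyano group yet lie well apart, which shows that cyano alone does not set the value and that the aromatic ring on the shared core also counts.

No measurement at hand gives a reason for either fall. Going by these compounds, it remains open where a methoxy or a trifluoromethyl group on this ring carbon would fall relative to chloro and cyano, and whether the swap from chloro to cyano would give a step of this size with the shorter ethoxy side chain of compound 3 or with the 2-chlorophenyl group of compound 1.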